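Swapping the Ring Nitrogen Substituent on a Dichlorophenyl Glutarimide

A few compounds are considered here, and "the series" means these few. Any claim that something is new, unique, unknown or untested is made for them only; others in the source may bear on it.

Measured so far:
Compound 1, `Cc1ccccc1N1C(=O)C(c2ccccc2)CC(c2ccccc2)C1=O`: 66.1%
Compound 2, `CN1C(=O)C(c2ccccc2Cl)CC(c2ccccc2Cl)C1=O`: 61.7%

In a functional assay on the whole organism (strain Swiss albino) for inhibition, with Mus musculus as the target, in the maximal electroshock model, with a stated time of 2 h, at a dose of 25 mg/kg by the intraperitoneal route (on this read-out higher numbers stand for more inhibition at the one dose given (going by the name of the read-out) and lower numbers for less inhibition), compound 1 gives 66.1%, and compound 2 gives 61.7%. Going by the values given here, of the two numbers, the one for compound 2 is the lower, yet its gap to compound 1 lies within the usual scatter, so the two compounds are not told apart by these data.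

Compound 3, `Cc1ccccc1N1C(=O)C(c2ccccc2Cl)CC(c2ccccc2Cl)C1=O`, has not yet been measured. It differs from compound 2 in one place: 2-methylphenyl in place of methyl on an amide-type nitrogen in a ring. Among the compounds with values here, no measured pair shows this single change on its own, so its effect is unknown from direct comparison. Both measured compounds carry large groups on the shared core and land close together, and on that basis the step of a number 2.3 percentage points higher from compound 2 to compound 3 (within the scatter) is expected to be small, in no clear direction beyond the scatter. Compound 3 is therefore estimated at 64%, within a range from 50% to 78%.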

Compound 3, a percentage reported as inhibition, in the whole organism at one dose (the size of the read-out at that dose, not a potency): 60.6%
Beside the measured number, compound 3's estimate is 3.4 percentage points above it; measured number inside the range.
By their numbers in this assay, from the lowest: compounds 3, 2 and 1 (each within the scatter of the next).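

Going by these compounds alone, the change to 2-methylphenyl in place of methyl on the amide-type nitrogen in a ring gives a number 1.1 percentage points lower from compound 2 to compound 3 (within the scatter) in this assay and is the first direct reading of this position with both 2-chlorophenyl groups held fixed. The entering group adds a six-membered aromatic ring and brings 7 heavy atoms where the methyl has 1, yet the two compounds are not told apart at this one dose, so this position takes both groups without a visible difference in this read-out. Nothing at hand gives a reason for this result.

On these data alone, whether the same holds for a very different group on this nitrogen, such as a carboxylic acid, an amine or a longer chain, stays open. A single dose and time also leaves open whether compound 2 and compound 3 would separate under other conditions.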